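The source may hold more compounds than are shown below. What is called first, only, known or untested is meant among the compounds shown, and "the series" means these compounds.

Compound 1, `C=CC1=C(C(=O)NCc2ccc(C)cc2)C(c2ccc(F)cc2)OC1`: 62100 nM
Compound 2, `C=CC1=C(C(=O)NCC(C)C)C(c2ccc(Cl)c(Cl)c2)OC1`: > 100000 nM
Compound 3, `C=CC1=C(C(=O)Nc2ccccc2)C(c2ccc(OC)cc2)OC1`: > 100000 nM

Of the compounds shown here, three built on the same core have been tested in a functional assay on QGY7701 cells (Homo sapiens) for cytotoxicity, read by MTT assay, with a stated time of 24 h; on this read-out higher numbers stand for weaker inhibition and lower numbers for stronger inhibition. Compound 1 is the only one that returns an actual number, 62100 nM, and that number is high, which on this read-out means weak inhibition. For compound 2 the result is a limit rather than a number, > 100000 nM. For compound 3 the result is likewise a limit, > 100000 nM. The picture is therefore dominated by the limit of > 100000 nM in this assay, at which 2 of the 3 values shown sit, with compound 1 standing just short of it.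

Compound 4, `C=CC1=C(C(=O)NC(C)(C)C)C(c2ccc(F)cc2)OC1`, has not yet been measured. It differs from compound 1 in a single place: tert-butyl in place of 4-methylbenzyl on an amide-type nitrogen. For the measured compounds named here, no measured pair of compounds differs in this same way, so the data give no direct guide to the direction of the change. What they do show is that all three measured compounds are weak, and the most likely outcome for compound 4 is a weak result as well. The expected step of a 1.4-fold higher number from compound 1 to compound 4 (0.16 log units; within the scatter) is small, toward slightly weaker inhibition, and within the usual scatter. Compound 4 is estimated at 90000 nM, with a range from 40000 nM to 200000 nM, and there is a fair chance that only a limit is reported.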

Compound 4, half-maximal inhibitory concentration: > 100000 nM
Compound 4: no number, only a limit; the forecaster's own chance of this, stated with the estimate: 45%; at least 1.1-fold (0.04 log units) between middle value and limit.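

For the compounds shown here, this is the first pair here that differs in one place only, so the group on the amide-type nitrogen can now be read directly: in this assay, tert-butyl in place of 4-methylbenzyl gives an at least 1.6-fold higher number from compound 1 to compound 4 (0.20 log units; that floor lies within the scatter). That figure is only a floor, since the result for compound 4 is a limit and not a number, and the floor does not clear the usual scatter, so the true gap could be small or much larger, and a real loss from this change cannot be claimed. What the change does show is that tert-butyl brings no measurable gain at this place, and the set now sits mostly at one edge of what the test can report: the limit of > 100000 nM in this assay, at which 3 of the 4 values shown sit.

As far as these compounds go, it remains open whether any group on this nitrogen can bring inhibition well clear of that limit, such as a chain ending in an amine or in a carboxylic acid. From the compounds shown here alone, it is also open whether a benzyl group without the 4-methyl would behave like the 4-methylbenzyl group of compound 1.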